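From compound 3 to compound 4: methyl for cyano

The compounds below may be only part of what the source reports. "The series", "measured", "known", "first", "only" and "open" are said of these compounds alone.

Compound 1 `N#Cc1ccc(-c2ccc(Cn3cccc(O)c3=O)cc2)cc1`: > 10 ug/mL
Compound 2 `N#Cc1cccc(-c2ccc(Cn3cccc(O)c3=S)cc2)c1`: > 10 ug/mL
Compound 3 `N#Cc1ccccc1-c1ccc(Cn2cccc(O)c2=O)cc1`: > 10 ug/mL

The three compounds were tested in an ADME assay on THP-1 cells (Homo sapiens) for cytotoxicity, read by resazurin assay, with a stated time of 48 h (on this read-out higher numbers stand for weaker inhibition and lower numbers for stronger inhibition), and none of them yielded a number. Compound 3 is reported as > 10 ug/mL, which is a limit of the assay and not a measured value. It has plenty of company, as the set shows (the limit of > 10 ug/mL in this assay, at which 3 of the 3 values shown sit).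

Compound 4 `Cc1ccccc1-c1ccc(Cn2cccc(O)c2=O)cc1` changes compound 3 in one place: methyl in place of cyano on an aromatic carbon. In words, this is methyl in place of cyano on an aromatic carbon, ortho to a large group. Within the data shown here, no measured pair in the set shows this change, so the data give no direct guide to its size. The expectation rests on the limit of compound 3 at > 10 ug/mL. The estimated step that the limit leaves unreadable from compound 3 to compound 4 stays within the usual scatter, with no direction expected in this assay. A report at the same limit is therefore the likeliest outcome.

Compound 4 is estimated at 14 ug/mL, with an expected range from 7 ug/mL to 40 ug/mL.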

Compound 4, half-maximal inhibitory concentration: > 10 ug/mL
Compound 4: only a limit was reported (the forecaster's own chance of this, stated with the estimate: 75%); the middle value lies beyond the limit too.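

In this assay, compound 3 and compound 4 are both reported only as limits, so no step can be read for methyl in place of cyano: the limit of > 10 ug/mL in this assay, at which 4 of the 4 values shown sit. The compounds shown leave open at what concentration any of them would reach half-maximal inhibition.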